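Trading a Silicon-Bearing Group for Hydrogen on Compound 2

The compounds below may be only part of what the source reports. "The series", "measured", "known", "first", "only" and "open" are said of these compounds alone.

Compound 1, `CCOC(CCn1c(Cc2nn(C)c(=O)c3ccccc23)nnc1SCCCCCCCC(=O)Nc1ccc(Cl)cc1Cl)OCC`, was tested in an assay on 32D cells for inhibition of interleukin-15 (Mus musculus), read by resazurin assay, with stated times of 30 min and 2.5 days, in the presence of a further agent that is not named here (a higher number here means a weaker inhibitor, a lower number a stronger inhibitor), where compound 1 gives 12100 nM. Compound 2, `Cn1nc(Cc2nnc(SCCCCCCCC(=O)Nc3ccc(Cl)cc3Cl)n2CCCO[Si](C)(C)C(C)(C)C)c2ccccc2c1=O`, differs from it in one place. For compound 2 this assay reports only a limit of > 30000 nM, not a number. The step shows an at least 2.4-fold higher number from compound 1 to compound 2 (0.39 log units; beyond the scatter); the size rests on (the limit of > 30000 nM in this assay, at which 1 of the 2 values shown sits), so compound 2 stands only as a limit on the numbers shown.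

Compound 3, `Cn1nc(Cc2nnc(SCCCCCCCC(=O)Nc3ccc(Cl)cc3Cl)n2CCCO)c2ccccc2c1=O`, is not yet measured. It differs from compound 2 by a hydrogen atom in place of a group of 7 heavy atoms (6 carbon, 1 silicon; no ring), on an oxygen on a saturated carbon. Among the compounds with values here, the only measured step touches the same end of the same chain, and it gave an at least modest move toward weaker inhibition when a larger group replaced a smaller one. Compound 3 moves the other way, to the smallest possible substituent there, so a return toward the number of compound 1, or no step beyond the scatter, is expected. Compound 3 is therefore estimated at 15000 nM, within 5000 nM to 45000 nM, which means an expected step of an at least 2.0-fold lower number from compound 2 to compound 3 (0.30 log units; that floor lies within the scatter).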

Compound 3, half-maximal inhibitory concentration: > 30000 nM
Compound 3: a limit, no number; the forecaster's own chance of this, stated with the estimate: 35%; at least 2.0-fold (0.30 log units) between middle value and limit.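

With the silicon-bearing group gone and only a hydrogen left on that oxygen, compound 3 still gives no number in this assay, only the assay limit of > 30000 nM. Compound 2 and compound 3 thus end at the same limit despite this large change in the group on the oxygen, so the step between them cannot be read, and of the three compounds only compound 1, with its diethoxymethyl group, has a measured number: the limit of > 30000 nM in this assay, at which 2 of the 3 values shown sit. The comparison with compound 1 can be read, and it shows an at least 2.4-fold higher number from compound 1 to compound 3 (0.39 log units; beyond the scatter), so hydroxymethyl in place of diethoxymethyl on this saturated chain carbon does not keep the inhibition seen for compound 1.

On these data alone, how far the true values of compound 2 and compound 3 lie past the limit remains unknown, and so does which of the two is the weaker inhibitor. Also open, as far as these compounds go, is whether an amine or a carboxylic acid at the end of this chain, or a longer chain, would give a measurable number, and whether any such number would be lower than that of compound 1.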